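The source may report more compounds than this note shows. Statements on the series, on what has been measured and on what is new or still open speak of the compounds shown alone.

Measured compounds in the series:

- compound 1 `CC[C@H](C)/N=c1\c(O)c(O)\c1=N/Cc1ccc(C#N)cc1` — 2200 nM
- compound 2 `CC(C)(CO)/N=c1\c(O)c(O)\c1=N/Cc1ccc(C#N)cc1` — 21300 nM
- compound 3 `CCC(C)(C)/N=c1\c(O)c(O)\c1=N/Cc1ccc(C#N)cc1` — 1100 nM

In a functional assay for inhibition, with Rattus norvegicus as the target (a lower number here means a stronger inhibitor, a higher number a weaker inhibitor), compound 3 gives 1100 nM, the lowest number of the three; compound 1 lies a 2.0-fold lower number from compound 1 to compound 3 (0.30 log units; within the scatter) away, a gap within the scatter, so compound 3 and compound 1 are not separable, while compound 2 stands far off at a 19-fold lower number from compound 2 to compound 3 (1.29 log units; beyond the scatter).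

Compound 4 `CCC/N=c1\c(O)c(O)\c1=N/Cc1ccc(C#N)cc1` is yet to be measured in this assay. It differs from compound 3 as follows: propyl in place of 1,1-dimethylpropyl on a double-bonded nitrogen.

Going by the values given here, the only measured step touching the same position is the one between compound 1 and compound 3, a 2.0-fold lower number from compound 1 to compound 3 (0.30 log units; within the scatter), which is within the scatter: trading sec-butyl for 1,1-dimethylpropyl changed little. The other steps, a 9.7-fold higher number from compound 1 to compound 2 (0.99 log units; beyond the scatter) and a 19-fold lower number from compound 2 to compound 3 (1.29 log units; beyond the scatter), involve a hydroxy group and do not bear on a propyl chain. Two alkyl groups on the double-bonded nitrogen gave numbers within the scatter of one another; a shorter, unbranched propyl is a step outside what has been tried, so some weakening is plausible but not established. For compound 4 a small rise is expected, a 2.7-fold higher number from compound 3 to compound 4 (0.44 log units; beyond the scatter), with compound 4 estimated at 3000 nM (range 1200 nM to 8000 nM).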

Compound 4, half-maximal inhibitory concentration: 21900 nM
The estimate for compound 4 lay 7.3-fold (0.86 log units) below the measured number, outside the stated range (above it).
By their numbers in this assay, from the lowest: compounds 3 and 1 (each within the scatter of the next); then compounds 2 and 4 (each within the scatter of the next).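

In this assay the group on the double-bonded nitrogen, which looked tolerant when sec-butyl and 1,1-dimethylpropyl were compared, now proves sensitive: propyl in place of 1,1-dimethylpropyl gives a 20-fold higher number from compound 3 to compound 4 (1.30 log units; beyond the scatter) and hydrogen in place of methyl on the chain carbon bound to that nitrogen gives a 10-fold higher number from compound 1 to compound 4 (1.00 log units; beyond the scatter). Branching at that carbon is not enough on its own, as 1-(hydroxymethyl)-1-methylethyl and propyl cannot be separated, at a 1.0-fold higher number from compound 2 to compound 4 (0.01 log units; within the scatter). Nothing available explains these steps.

Still open, as far as these compounds go, is whether the low numbers depend on the branching itself or on the size of the group, which a longer unbranched chain such as pentyl or a ring such as cyclopentyl would help to separate. From the compounds shown here alone, it is also open whether a methoxy or an amine in place of the hydroxy of compound 2 would behave like the hydroxy or like methyl.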